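Trading an Ethylphenyl Group for a Dichlorophenyl Group

This account rests on a few compounds, and the source may have more. Where it says the series, first, only, none or still open, it means among the compounds named here.

Compound 1, `CCc1ccc(NCC(=O)Nn2c(-c3ccccc3)nc3ccccc3c2=O)cc1`: 2100 nM
Compound 2, `O=C1N=C(NN2Cc3ccccc3N=C2c2ccccc2)S/C1=C/c1ccc(O)cc1O`: 3220 nM

Both compounds were tested in a functional assay on A549 cells (Homo sapiens) for cytotoxicity, read by MTT assay, with a stated time of 4 h; a higher number here means a weaker inhibitor, a lower number a stronger inhibitor. Compound 1 gives 2100 nM there, and compound 2 gives 3220 nM; the gap between the two numbers lies within the usual scatter, so neither compound can be set apart from the other. For the measured compounds named here, no pair of measured compounds differs in only one place, so there is no measured step to lean on.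

Compound 3, `O=C(CNc1ccc(Cl)cc1Cl)Nn1c(-c2ccccc2)nc2ccccc2c1=O`, has not yet been measured in this assay. It differs from compound 1 in one way: 2,4-dichlorophenyl in place of 4-ethylphenyl on an amine nitrogen. Going by the values given here, with no measured step available, the expectation for this change rests on the two numbers alone. Compound 3 is estimated to move by a 1.2-fold higher number from compound 1 to compound 3 (0.08 log units; within the scatter) from compound 1, a shift that is expected to stay within the scatter rather than mark a clear gain or loss. The value of compound 3 in this assay is therefore expected to be about 2500 nM, with a range from 800 nM to 8000 nM.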

Compound 3, half-maximal inhibitory concentration: 187000 nM
Compound 3: middle estimate off by 75-fold (1.87 log units), on the low side; the measured number lies above the stated range.
By their numbers in this assay, from the lowest: compounds 1 and 2 (each within the scatter of the next); then compound 3.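

In this assay, the group on the amine nitrogen proves to be far from a neutral place on this scaffold: the change to 2,4-dichlorophenyl gives an 89-fold higher number from compound 1 to compound 3 (1.95 log units; beyond the scatter), even though the two groups hold the same number of heavy atoms and each is one six-membered aromatic ring of carbon only. For the compounds shown here, compound 1 and compound 2 differ in more than one place and could say nothing about this position, so this step is the first direct reading of it, and of these two groups 4-ethylphenyl goes with the much lower number. Nothing measured here accounts for the size of the step.

The compounds shown leave open whether the step comes from losing the ethyl group, from gaining the chlorines, or from both together, since this one change does all of that at once; a plain phenyl group, or a phenyl group carrying a single chlorine, would begin to separate these readings. They also leave open whether the same change would have a similar effect on any other core, as the finding rests on this single pair.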